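The source may hold more compounds than are shown below. What is called first, only, known or untested is meant among the compounds shown, and "the series" means these compounds.

Measured compounds:
compound 1 `Cc1nn(-c2ncnc3nc[nH]c23)c2c1C(OCC(=O)c1ccc(F)cc1)CC(=O)N2` — 3 nM
compound 2 `CCCCCCCCOC1CC(=O)Nc2c1c(C)nn2-c1ncnc2nc[nH]c12` — 8 nM
compound 3 `Cc1nn(-c2ncnc3nc[nH]c23)c2c1C(OCc1ccc(C(C)C)cc1)CC(=O)N2` — 5 nM

In a functional assay on HEK293 cells for agonist activity at G-protein coupled receptor 39 (Homo sapiens), read by scintillation proximity assay and inositol phosphate accumulation, with a stated time of 75 min, in the presence of a further agent that is not named here (on this read-out higher numbers stand for an effect only at larger amounts of compound and lower numbers for an effect already at smaller amounts), compound 2 gives the highest of the three numbers. Its nearest neighbour is compound 3, a 1.6-fold lower number from compound 2 to compound 3 (0.20 log units; within the scatter), a gap within the scatter; its furthest is compound 1, a 2.7-fold higher number from compound 1 to compound 2 (0.43 log units; beyond the scatter). Between compound 1 and compound 3 the gap is a 1.7-fold higher number from compound 1 to compound 3 (0.22 log units; within the scatter).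

Compound 4 `Cc1nn(-c2ncnc3nc[nH]c23)c2c1C(C(=O)N(C)c1nccs1)CC(=O)N2` differs from compound 2 in one place: methyl(1,3-thiazol-2-yl)carbamoyl in place of octyloxy on a saturated ring carbon. All three measured steps exchange only the group carried on the oxygen at that saturated ring carbon and keep the ether oxygen itself; none of them removes the oxygen or introduces a carbamoyl group, so none bears directly on this change. Those three steps were small, the largest being a 2.7-fold higher number from compound 1 to compound 2 (0.43 log units; beyond the scatter), which shows the position tolerating varied ether substituents without large swings in this assay. The new change reaches further than any measured step, so the expectation is correspondingly uncertain.

Compound 4 is expected to give 30 nM, with a range from 5 nM to 300 nM. The expected step is a 3.8-fold higher number from compound 2 to compound 4 (0.57 log units; beyond the scatter).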

Compound 4, half-maximal effective concentration: 18 nM
For compound 4 the middle estimate is 1.7-fold (0.22 log units) above the measured one; low and high end bracket the measured number.
By their numbers in this assay, from the lowest: compounds 1, 3 and 2 (each within the scatter of the next, the first and the last beyond it); then compound 4.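

In this assay the saturated ring carbon also accepts a carbamoyl group bound directly to it, without the ether oxygen kept in all earlier steps: methyl(1,3-thiazol-2-yl)carbamoyl in place of octyloxy gives a modest step (a 2.3-fold higher number from compound 2 to compound 4 (0.35 log units; beyond the scatter)). The effect thus survives loss of the ether link and entry of a five-membered aromatic ring, although compound 4 gives the highest number of the four compounds. Nothing available explains the size of this step.

Link and end group change together here, so the compounds shown cannot assign the step to either one. Open too, going by these compounds, is how a dimethylcarbamoyl group, a carboxylic acid or an octyl chain bound directly to this ring carbon would read.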